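The source may report more compounds than this note shows. Statements on the series, on what has been measured and on what is new or still open speak of the compounds shown alone.

Measured compounds:
compound 1, `CC1=C(C(=O)OCC2CCCCC2)C(c2cccc(O)c2)NC(=S)N1` — > 10000 nM
compound 2, `CCC1=C(C(=O)OCC2CCCCC2)C(c2cccc(O)c2)NC(=S)N1` — > 10000 nM
compound 3, `CCC1=C(C(=O)OCC2CCCCC2)C(c2cccc([N+](=O)[O-])c2)NC(=O)N1` — > 10000 nM

In an ADME assay on CEMx174 cells (Homo sapiens) for cytotoxicity (on this read-out lower numbers stand for higher toxicity in this test and higher numbers for lower toxicity in this test), compound 1 gives > 10000 nM, which is a limit of the assay and not a number. Compound 2 gives > 10000 nM, again only a limit. The step that the two limits leave unreadable from compound 1 to compound 2 therefore cannot be sized. Compound 3 gives > 10000 nM, once more a limit. Compound 3 thus stands where every value shown stands, at the limit of > 10000 nM in this assay, at which 3 of the 3 values shown sit, with no numeric value to place it above or below the others.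

Compound 4, `CCC1=C(C(=O)OCC2CCCCC2)C(c2ccc(Cl)cc2)NC(=O)N1`, differs from compound 3 in one place: 4-chlorophenyl in place of 3-nitrophenyl on a saturated ring carbon. Within the data shown here, no measured step touches this change; the only step on record, from compound 1 to compound 2, concerns the ethyl group and is itself unreadable. With three of three values at the limit, compound 4 is expected to show no step beyond the scatter, that is a step that the limit leaves unreadable from compound 3 to compound 4. The estimate for compound 4 is 15000 nM, with a range from 7000 nM to 50000 nM, and most likely it too is reported only as a limit.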

Compound 4, half-maximal cytotoxic concentration: > 10000 nM
Compound 4: a limit, no number; the forecaster's own chance of this, stated with the estimate: 85%; the middle value is on the limit's open side.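

In this assay, among these compounds, compound 4 gives > 10000 nM, a limit and not a number, so no step from compound 3 to compound 4 can be read. The compounds shown leave open at what concentration any of them turns toxic in this test, and whether 4-chlorophenyl and 3-nitrophenyl differ at all, with every value at one place: the limit of > 10000 nM in this assay, at which 4 of the 4 values shown sit.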